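Allyl amide series on a thiophene cyclopropane core: next step

This account rests on a few compounds, and the source may have more. Where it says the series, first, only, none or still open, it means among the compounds named here.

Measured compounds:
compound 1, `C=CCN(C)C(=O)[C@@]1(c2ccsc2)C[C@H]1CN` — > 10000 nM
compound 2, `C=C(F)CN(C)C(=O)[C@@]1(c2ccsc2)C[C@H]1CN` — > 10000 nM
compound 3, `COCCN(C)C(=O)[C@@]1(c2ccsc2)C[C@H]1CN` — > 10000 nM

Compound 1 stands only at a limit in an assay on HEK293 cells for inhibition of sodium-dependent dopamine transporter (Homo sapiens); on this read-out lower numbers stand for stronger inhibition and higher numbers for weaker inhibition: its value, > 10000 nM, is a limit of the assay and not a number. Compound 2 likewise gives a limit, > 10000 nM. Compound 3 also gives a limit, > 10000 nM. All three sit at the limit of > 10000 nM in this assay, at which 3 of the 3 values shown sit, so the steps a step that the two limits leave unreadable from compound 1 to compound 2, a step that the two limits leave unreadable from compound 1 to compound 3 and a step that the two limits leave unreadable from compound 2 to compound 3 cannot be sized.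

The unmeasured compound 4, `C=CCN(CC=C)C(=O)[C@@]1(c2ccsc2)C[C@H]1CN`, differs from compound 1 by vinyl in place of hydrogen on a saturated chain carbon bound to an amide-type nitrogen. Every measured step in this assay changes the same chain on the amide-type nitrogen or a group on it, and none of them brought a value below the limit. For the measured compounds named here, the change to compound 4 is of the same kind, in the same place, and no measured step gives a readable size to build on.

Compound 4 is therefore expected to remain at the limit as well, with the estimated step that the limit leaves unreadable from compound 1 to compound 4 carrying no readable size. For compound 4 the estimate is 20000 nM, in the range 5000 nM to 100000 nM.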

Compound 4, half-maximal inhibitory concentration: 8300 nM
Beside the measured number, compound 4's estimate is 2.4-fold (0.38 log units) above it, within the range that was stated.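

In this assay, compound 4 is the only compound shown that gives a number and not a limit: the limit of > 10000 nM in this assay, at which 3 of the 4 values shown sit.

Vinyl in place of hydrogen on a saturated chain carbon bound to an amide-type nitrogen, which also reads as methyl to allyl, gives an at least 1.2-fold lower number from compound 1 to compound 4 (0.08 log units; that floor lies within the scatter). Compound 1 gives > 10000 nM, which is a limit of the assay and not a number, so only a floor can be read for this step, and the steps among compounds 1, 2 and 3 cannot be read at all.

The compounds shown leave open whether a propyl group, a longer saturated chain or a benzyl group in place of the methyl of compound 1 would also give a number in this assay, and so whether the double bond of the allyl group matters or the added chain alone. Also open, on these data alone, is whether a value well clear of the scatter can be reached from compound 4 by further change on this amide-type nitrogen.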